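The compounds below may be only part of what the source reports. "The series", "measured", "known", "first", "only" and "open" are said of these compounds alone.

Measured so far in a functional assay on HeLa cells (Homo sapiens) for cytotoxicity, read by MTT assay, with a stated time of 72 h, tested at 10 uM; on this read-out lower numbers stand for less inhibition of growth and higher numbers for more inhibition of growth at the one concentration tested:
compound 1 `N/C(=N\NC(=S)N1CCCCCC1)c1ccccn1` with 67.4%
compound 2 `Cc1ccnc(/C(N)=N/NC(=S)N2CCSCC2)c1` with 39.2%
compound 3 `N/C(=N\NC(=S)N1CCSCC1)c1ccccn1` with 54.5%

Compound 2 stands lowest of the three in this assay; the nearest of the others lies a number 15.3 percentage points higher from compound 2 to compound 3 (beyond the scatter), and compound 1 lies furthest. Compound 4 `Cc1ccnc(/C(N)=N/NC(=S)N2CCCC2)c1` differs from compound 2 by pyrrolidin-1-yl in place of thiomorpholin-4-yl on a thiocarbonyl carbon. Going by the values given here, the one measured step, a number 15.3 percentage points higher from compound 2 to compound 3 (beyond the scatter), alters the aromatic carbon and leaves the ring on the thiocarbonyl carbon untouched, so it does not bear on this change. Among the compounds with values here, compound 1 and compound 3, which carry different rings on the thiocarbonyl carbon, show only that their two values lie apart. Within the data shown here, with no directly comparable step, the number for compound 4 is expected to move by a number 10.8 percentage points higher from compound 2 to compound 4 (beyond the scatter). Compound 4 is estimated at 50%, between 30% and 70%.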

Compound 4, percent growth inhibition at one concentration: 67%
The estimate for compound 4 lay 17 percentage points below the measured number; low and high end bracket the measured number.
By their numbers in this assay, from the lowest: compound 2; then compound 3; then compounds 4 and 1 (each within the scatter of the next).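

In this assay, the ring on the thiocarbonyl carbon turns out to matter: pyrrolidin-1-yl in place of thiomorpholin-4-yl gives a number 27.8 percentage points higher from compound 2 to compound 4 (beyond the scatter). This is the first single change at this position among the compounds shown, and it moves the read-out beyond the scatter with the methyl on the aromatic carbon kept in place. Nothing available accounts for this step.

From the compounds shown here alone, it remains open how a piperidin-1-yl or morpholin-4-yl ring, or an open-chain dimethylamino group, would read at this position. Going by these compounds, whether pyrrolidin-1-yl gives a similar step with hydrogen in place of that methyl also remains open.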